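Adding a Methoxy Group to Compound 1

A few compounds are considered here, and "the series" means these few. Any claim that something is new, unique, unknown or untested is made for them only; others in the source may bear on it.

Compound 1 `COc1cccc(/C=C2\CCC/C(=C\c3ccc(OC)c(OC)c3)C2=O)c1`: 4600 nM
Compound 2 `COc1ccc(/C=C2\CCC/C(=C\c3cccc(Cl)c3Cl)C2=O)cc1OC`: 14300 nM
Compound 3 `COc1ccc(/C=C2\CCC/C(=C\c3ccc(Cl)cc3Cl)C2=O)cc1OC`: 16200 nM

In a functional assay on MCF7 cells (Homo sapiens) for cytotoxicity, read by MTT assay, with a stated time of 72 h (a higher number here means a weaker inhibitor, a lower number a stronger inhibitor), compound 1 has the lowest number of the three compounds measured. The two steps away from it are modest: a 3.1-fold higher number from compound 1 to compound 2 (0.49 log units; beyond the scatter) and a 3.5-fold higher number from compound 1 to compound 3 (0.55 log units; beyond the scatter). The remaining pair differs little, with a 1.1-fold higher number from compound 2 to compound 3 (0.05 log units; within the scatter). Compound 4 `COc1ccc(/C=C2\CCC/C(=C\c3ccc(OC)c(OC)c3)C2=O)cc1OC` is not yet measured and differs from compound 1 as follows: methoxy in place of hydrogen on an aromatic carbon. Neither step from compound 1 tests this change directly, since both replace the whole 3-methoxyphenyl group with a dichlorophenyl group. Only a small step of uncertain direction is therefore expected in this assay, possibly none beyond the scatter. The expected step is a 1.2-fold lower number from compound 1 to compound 4 (0.06 log units; within the scatter). Compound 4 is estimated at 4000 nM, with an expected range of 1500 nM to 11000 nM.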

Compound 4, half-maximal inhibitory concentration: 13500 nM
Compound 4: middle estimate off by 3.4-fold (0.53 log units), on the low side; measured number above the stated range.
By their numbers in this assay, from the lowest: compound 1; then compounds 4, 2 and 3 (each within the scatter of the next).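

In this assay, methoxy in place of hydrogen, on an aromatic carbon ortho to a methoxy group and para to a large group, gives a 2.9-fold higher number from compound 1 to compound 4 (0.47 log units; beyond the scatter). Going by these compounds alone, this is the first direct reading of this position, as the earlier steps replaced the whole 3-methoxyphenyl group, and it shows that this single addition alone raises the number. Nothing available accounts for the rise. The compounds shown leave open whether a hydroxyl, a fluorine or an ethoxy on this carbon would raise the number as methoxy does.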